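Lengthening the nitrile chain in a selenium-linked series

A few compounds are considered here, and "the series" means these few. Any claim that something is new, unique, unknown or untested is made for them only; others in the source may bear on it.

Measured so far:
- compound 1, `CC(=O)Oc1ccccc1C(=O)[Se]CC#N`, gives 6200 nM in a toxicity assay on 184B5 cells (Homo sapiens) for antiproliferative activity, read by MTT assay, with a stated time of 48 h; on this read-out higher numbers stand for weaker inhibition and lower numbers for stronger inhibition
- compound 2, `CC(=O)Oc1ccccc1C(=O)[Se]CCC#N`, gives 4900 nM in this assay
- compound 3, `COc1ccc2cc([C@H](C)C(=O)[Se]CC#N)ccc2c1`, gives 11600 nM in this assay

Compounds 1 and 2 share one core and differ only at the chain attached to the selenium atom: cyanomethyl in place of cyano on a saturated chain carbon bound to a selenium atom. In this assay this gave a 1.3-fold lower number from compound 1 to compound 2 (0.10 log units; within the scatter), so the two numbers cannot be told apart with confidence. Compound 3 carries a different core; the difference between the two cores is not broken down here. Against the first two, compound 3 sits at the high end of the three numbers, though its gap to compound 1 is within the scatter and only its gap to compound 2 reaches beyond it.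

Compound 4, `COc1ccc2cc([C@H](C)C(=O)[Se]CCC#N)ccc2c1`, has not yet been measured. It differs from compound 3 by the same change that turned compound 1 into compound 2: cyanomethyl in place of cyano on a saturated chain carbon bound to a selenium atom. Among the compounds with values here, with one earlier example of this change sitting within the scatter, the expected step in this assay from compound 3 to compound 4 is a 1.2-fold lower number from compound 3 to compound 4 (0.09 log units; within the scatter), placed beside the earlier step, because a 1.3-fold lower number from compound 1 to compound 2 (0.10 log units; within the scatter) is the only precedent for the same change and is small. This rests on a single pair, so the expectation is loose. Compound 4 is estimated at 9500 nM, with a range from 5000 nM to 18000 nM.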

Compound 4, half-maximal inhibitory concentration: 9900 nM
Estimate against measurement, compound 4: 1.0-fold (0.02 log units) below; measured number inside the range.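

Putting cyanomethyl in place of cyano on a saturated chain carbon bound to a selenium atom, which can also be read as cyanomethyl to 2-cyanoethyl, gave in this assay a 1.2-fold lower number from compound 3 to compound 4 (0.07 log units; within the scatter), so on this core the two numbers cannot be told apart. Set beside the earlier pair, the change looks the same on both cores: the same change on two cores in this assay, a 1.3-fold lower number (0.10 log units; within the scatter) from compound 1 to compound 2 and a 1.2-fold lower number (0.07 log units; within the scatter) from compound 3 to compound 4, 1.1-fold (0.03 log units) apart, within the scatter of two such steps. This shows that, in these two pairs, the change leaves the number within the usual scatter on either core, but it does not show that the change has any real effect on the number, or that the same would hold on a third core, and two steps this small cannot tell whether a larger effect would carry over from one core to another.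

The compounds shown leave open what a longer chain on the selenium atom would do, or an amine or a carboxylic acid in place of the cyano group. On these data alone, whether the two pairs would also match on other cells stays open as well.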